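Two measured compounds, and a thioether in the place of the ether

The compounds below may be only part of what the source reports. "The series", "measured", "known", "first", "only" and "open" are said of these compounds alone.

Measured so far:
compound 1, `Nc1cc(N)c2nc(-c3ccccc3)c(Oc3ccc(Cl)c(Cl)c3)nc2c1`, 3470 nM
compound 2, `COc1cc(CNc2nc3cc(N)cc(N)c3nc2-c2ccccc2)cc(OC)c1OC`, 692 nM

In a functional assay on RPMI8266 cells (Homo sapiens) for inhibition, read by sulforhodamine B assay, with a stated time of 48 h (on this read-out higher numbers stand for weaker inhibition of growth and lower numbers for stronger inhibition of growth), compound 1 gives the higher of the two numbers; compound 2 comes in lower. Compound 3, `Nc1cc(N)c2nc(-c3ccccc3)c(Sc3ccc(F)cc3)nc2c1`, is not yet measured. It differs from compound 1 by (4-fluorophenyl)sulfanyl in place of 3,4-dichlorophenoxy on an aromatic carbon. For the measured compounds named here, no measured pair isolates such an exchange, so its effect is open. Since compound 2 reaches 692 nM with a quite different change, a modest move toward stronger inhibition is expected for compound 3 in this assay: a 1.4-fold lower number from compound 1 to compound 3 (0.14 log units; within the scatter). Compound 3 is estimated at 2500 nM, within a range of 700 nM to 9000 nM.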

Compound 3, concentration for 50% growth inhibition: 28200 nM
Compound 3: the middle estimate sits 11-fold (1.05 log units) below what was measured, and the stated range ends below it.
By their numbers in this assay, from the lowest: compound 2; then compound 1; then compound 3.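

In this assay this position proves sensitive to the exchange: (4-fluorophenyl)sulfanyl in place of 3,4-dichlorophenoxy gives an 8.1-fold higher number from compound 1 to compound 3 (0.91 log units; beyond the scatter) and thus weaker inhibition of growth. The entering and leaving groups each carry one six-membered aromatic ring of carbon only, but they differ in both the linking atom and the halogens, and this single step cannot separate those changes. Nothing measured here accounts for the loss. From the compounds shown here alone, it remains open how 4-fluorophenoxy or (3,4-dichlorophenyl)sulfanyl would read on this carbon, which would separate the two changes. Going by these compounds, an amine in this place also remains open.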